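A few compounds are considered here, and "the series" means these few. Any claim that something is new, unique, unknown or untested is made for them only; others in the source may bear on it.

Measured so far:
compound 1, `CNc1nc(NCc2ccc(NC(=O)c3ccncc3)cc2)c2ccccc2n1`: in a functional assay on SW480 cells (Homo sapiens) for inhibition, read by luminescence and resazurin assay, with a stated time of 3 days (a lower number here means a stronger inhibitor, a higher number a weaker inhibitor), compound 1 is recorded only as a limit, > 20000 nM.
compound 2, `CNc1nc(NCc2ccc(NC(=O)c3ccc(F)cc3)cc2)c2ccccc2n1`: in this assay compound 2 gives 2000 nM.
compound 3, `CNc1nc(NCc2ccc(NC(=O)c3ccc(CN4CCN(C)CC4)cc3)cc2)c2ccccc2n1`: in this assay compound 3 gives 11000 nM.

Compound 2 holds the lowest of the two numbers in this assay; its nearest neighbour is compound 3, reached by a 5.5-fold higher number from compound 2 to compound 3 (0.74 log units; beyond the scatter). Compound 1 sits at the limit of > 20000 nM in this assay, at which 1 of the 3 values shown sits, so its value is a limit and not a number, and the step of an at least 10-fold lower number from compound 1 to compound 2 (1.00 log units; beyond the scatter) is a lower bound only. Both measured steps alter the group on the carbonyl carbon of the amide: a 4-fluorophenyl in place of pyridin-4-yl, then a (4-methylpiperazin-1-yl)methyl in place of fluoro on that aryl.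

The unmeasured compound 4, `CNc1nc(NCc2ccc(NC(=O)c3ccc(F)cc3)cc2Cl)c2ccccc2n1`, differs from compound 2 by chloro in place of hydrogen on an aromatic carbon. Neither measured step touches the ring that carries the amide nitrogen, so neither bears directly on this change; the amide aryl of compound 2, the best of the measured set, is kept intact. For the measured compounds named here, with no precedent, the expectation for this assay is a step of about the size of the scatter, in either direction. Compound 4 is therefore estimated at 2000 nM, with a range of 700 nM to 6000 nM, which is expected to correspond to no change at the digits printed from compound 2 to compound 4 (within the scatter).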

Compound 4, half-maximal inhibitory concentration: 2300 nM
For compound 4 the middle estimate is 1.2-fold (0.06 log units) below the measured one; measured number inside the range.
By their numbers in this assay, from the lowest: compounds 2 and 4 (each within the scatter of the next); then compound 3. At a limit, above all of these: compound 1.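

In this assay, chloro in place of hydrogen gives a 1.2-fold higher number from compound 2 to compound 4 (0.06 log units; within the scatter), the only step shown on the ring that carries the amide nitrogen. This aromatic carbon, ortho to a large group and meta to a ((4-fluorophenyl)carbonyl)amino group, therefore takes a single chlorine with no change that can be read in this assay, whereas a change on the amide aryl, such as a 5.5-fold higher number from compound 2 to compound 3 (0.74 log units; beyond the scatter), lies beyond the scatter. No information shown here explains the result at this position.

From the compounds shown here alone, the reading rests on chloro alone and on the 4-fluorophenyl amide of compound 2, so it remains open whether a methoxy group, a primary amine or a carboxylic acid on the same carbon would also stay within the scatter of compound 2, or would separate from it clearly. Going by these compounds, it also remains open whether chloro at this carbon would leave the number unchanged with the (4-methylpiperazin-1-yl)methyl group of compound 3 on the amide aryl, and whether a second substituent on this ring would do the same.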